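Side-chain variation in a three-compound agonist set

A few compounds are considered here, and "the series" means these few. Any claim that something is new, unique, unknown or untested is made for them only; others in the source may bear on it.

All numbers below come from a functional assay on HEK293 cells for agonist activity at G-protein coupled receptor 39 (Homo sapiens), read by scintillation proximity assay and inositol phosphate accumulation, with a stated time of 75 min, in the presence of a further agent that is not named here; a lower number here means that less compound is needed, a higher number that more compound is needed for the effect.

compound 1, `Cc1nn(-c2ncnc3nc[nH]c23)c2c1C(OCc1ccc(Cl)cc1Cl)CC(=O)N2`: 4 nM
compound 2, `Cc1nn(-c2ncnc3nc[nH]c23)c2c1C(C(=O)NCc1ccccc1)CC(=O)N2`: 5 nM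
compound 3, `Cc1noc(C)c1COC1CC(=O)Nc2c1c(C)nn2-c1ncnc2nc[nH]c12`: 5 nM

Compound 3 stands level with compound 2 at the digits printed, and the two together give the highest numbers of the three. Against compound 1 the difference is a 1.3-fold higher number from compound 1 to compound 3 (0.10 log units; within the scatter), so all three sit inside the scatter of one another and no order can be read from them. The other two steps, a 1.3-fold higher number from compound 1 to compound 2 (0.10 log units; within the scatter) and no change at the digits printed from compound 2 to compound 3 (within the scatter), say the same: exchanging the whole group on the saturated ring carbon, whether an ether-linked aryl, a benzylcarbamoyl or an ether-linked heteroaryl, has left the number where it was.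

Compound 4, `Cc1nn(-c2ncnc3nc[nH]c23)c2c1C(OCCn1cccn1)CC(=O)N2`, differs from compound 3 as follows: (1H-pyrazol-1-yl)methyl in place of 3,5-dimethyl-1,2-oxazol-4-yl on a saturated chain carbon bound to an oxygen on a saturated carbon

Going by the values given here, the step that bears on this most directly is the one from compound 1 to compound 3, which also exchanges the group on the saturated chain carbon bound to an oxygen on a saturated carbon and stayed within the scatter; the steps through compound 2 point the same way. The expected step for compound 4 is therefore no change at the digits printed from compound 3 to compound 4 (within the scatter), with nothing beyond the scatter anticipated. Compound 4 is estimated at 5 nM, in the range 2 nM to 15 nM.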

Compound 4, half-maximal effective concentration: 16 nM
Beside the measured number, compound 4's estimate is 3.2-fold (0.51 log units) below it; measured number above the stated range.
By their numbers in this assay, from the lowest: compounds 1, 2 and 3 (each within the scatter of the next); then compound 4.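

The group on the saturated ring carbon does matter in this assay: replacing 3,5-dimethyl-1,2-oxazol-4-yl with (1H-pyrazol-1-yl)methyl on the saturated chain carbon bound to an oxygen on a saturated carbon gives a 3.2-fold higher number from compound 3 to compound 4 (0.51 log units; beyond the scatter), and the exchanges that had stayed within the scatter among compounds 1, 2 and 3 no longer describe the whole position. The other two steps agree, with a 3.2-fold higher number from compound 2 to compound 4 (0.51 log units; beyond the scatter) for 2-(1H-pyrazol-1-yl)ethoxy in place of benzylcarbamoyl and a 4.0-fold higher number from compound 1 to compound 4 (0.60 log units; beyond the scatter) for (1H-pyrazol-1-yl)methyl in place of 2,4-dichlorophenyl, so compound 4 stands apart from all three others, though each step is only modest. Both the leaving and the entering group count as one five-membered aromatic ring with 2 hetero atoms, with the same donor and acceptor counts, so those counts do not separate them, and nothing measured here accounts for the step.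

The compounds shown leave open whether the ring or the chain carries the step, since the 2-(1H-pyrazol-1-yl)ethoxy group differs from (3,5-dimethyl-1,2-oxazol-4-yl)methoxy in both. A (1H-pyrazol-1-yl)methoxy group and a 2-(3,5-dimethyl-1,2-oxazol-4-yl)ethoxy group on the same carbon would separate the two.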